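Lactam analogues in the keratinocyte growth series

This account rests on a few compounds, and the source may have more. Where it says the series, first, only, none or still open, it means among the compounds named here.

In an ADME assay on HaCaT cells (Homo sapiens) for inhibition, read by sulforhodamine B assay, with a stated time of 48 h (on this read-out lower numbers stand for stronger inhibition of growth and higher numbers for weaker inhibition of growth), compound 1 `COc1cc(/C=C/C2CC=CC(=O)O2)cc(OC)c1OC` gives 21.6 uM. Compound 2 `COc1ccc(/C=C/C2CC=CC(=O)N2)cc1OC` is known in this assay only as a limit, > 964 uM, and stands at the limit of > 964 uM in this assay, at which 1 of the 2 values shown sits. Compound 3 `COc1cc(/C=C/C2CC=CC(=O)N2)cc(OC)c1OC` differs from compound 2 by methoxy in place of hydrogen on an aromatic carbon. Among the measured compounds shown here, no step between measured compounds covers this change, so the size of the step of an at least 1.6-fold lower number from compound 2 to compound 3 (0.20 log units; that floor lies within the scatter) in this assay is expected to be small, with no clear direction beyond the usual scatter. Compound 3 is therefore estimated at 600 uM, within a range of 100 uM to 1500 uM.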

Compound 3, concentration for growth inhibition (reported as GI): > 864 uM
Compound 3: no number, only a limit (the forecaster's own chance of this, stated with the estimate: 60%); middle value at least 1.4-fold (0.15 log units) away from the limit.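

In this assay compound 3 gives > 864 uM, a limit of the assay and not a number. Compound 2 is also known only as a limit, so the step for methoxy in place of hydrogen on an aromatic carbon cannot be read. The exchange of the oxygen-containing group for the nitrogen-containing group on the double-bonded chain carbon now has a size, an at least 40-fold higher number from compound 1 to compound 3 (1.60 log units; beyond the scatter).

Going by these compounds, whether any substituent on the aromatic ring brings this nitrogen-containing series to a readable number remains open. An amine or a carboxylic acid at that carbon could test this.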